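Cytotoxicity notes on a bis-arylsulfonamide benzoxazole series

A few compounds are considered here, and "the series" means these few. Any claim that something is new, unique, unknown or untested is made for them only; others in the source may bear on it.

Measured compounds:
- Compound 1 `O=S(=O)(Nc1ccc(-c2nc3cc(NS(=O)(=O)c4ccccc4Cl)ccc3o2)cc1)c1ccccc1Cl` — in an ADME assay on FHC cells (Homo sapiens) for cytotoxicity, read by resazurin assay, with a stated time of 48 h (on this read-out higher numbers stand for lower toxicity in this test and lower numbers for higher toxicity in this test), compound 1 gives 45000 nM.
- Compound 2 `COc1ccc(S(=O)(=O)Nc2ccc3oc(-c4ccc(NS(=O)(=O)c5cc(F)ccc5OC)cc4)nc3c2)cc1` — in this assay compound 2 reaches only the limit of the assay, recorded as > 100000 nM.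
- Compound 3 `Nc1ccc(S(=O)(=O)Nc2ccc(-c3nc4cc(NS(=O)(=O)c5ccc(N)cc5)ccc4o3)cc2)cc1` — in this assay compound 3 gives 65000 nM.

All three compounds share one core and differ in the two aryl groups on the sulfonamide nitrogens. Compound 2 stands at the top end of what the assay can report: its value is a limit and not a number, and it is the only one of the three at that limit (the limit of > 100000 nM in this assay, at which 1 of the 3 values shown sits). Compound 1 and compound 3 both return measurable values, which lie within the scatter of each other.

Compound 4 `COc1ccc(S(=O)(=O)Nc2ccc3oc(-c4ccc(NC(=O)c5cccc(C)c5[N+](=O)[O-])cc4)nc3c2)cc1` is the next member. It keeps the methoxyphenylsulfonyl side of compound 2 and changes the other side: a group of 12 heavy atoms (8 carbon, 1 nitrogen, 3 oxygen; one six-membered aromatic ring of carbon only) in place of a group of 12 heavy atoms (7 carbon, 3 oxygen, 1 fluorine, 1 sulfur; one six-membered aromatic ring of carbon only), on a nitrogen on an aromatic ring in words: a group of 12 heavy atoms (8 carbon, 1 nitrogen, 3 oxygen; one six-membered aromatic ring of carbon only) in place of a group of 12 heavy atoms (7 carbon, 3 oxygen, 1 fluorine, 1 sulfur; one six-membered aromatic ring of carbon only), on a nitrogen on an aromatic ring. The sulfonamide on that side becomes a (3-methyl-2-nitrophenyl)carbonyl amide.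

Among the measured compounds shown here, no step between two measured compounds is available to anchor this change. Because compound 2 sits at the limit (the limit of > 100000 nM in this assay, at which 1 of the 3 values shown sits), the step in this assay can only be judged from the two measured neighbours, which themselves differ little; a step no larger than the scatter, or a modest move toward higher toxicity, is expected. Compound 4 is therefore expected to give 70000 nM, with a range of 30000 nM to 150000 nM. That estimate implies an expected step of an at least 1.4-fold lower number from compound 2 to compound 4 (0.15 log units; that floor lies within the scatter).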

Compound 4, half-maximal cytotoxic concentration: > 100000 nM
Compound 4 was reported as a limit (the forecaster's own chance of this, stated with the estimate: 40%); middle value at least 1.4-fold (0.15 log units) from the limit.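

No step can be read from compound 2 to compound 4, because both are recorded only as limits in this assay: the limit of > 100000 nM in this assay, at which 2 of the 4 values shown sit.

The compounds shown leave open whether (3-methyl-2-nitrophenyl)carbonyl in place of the departing group on that nitrogen changes the read-out at all.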